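The source may hold more compounds than are shown below. What is called first, only, known or untested is meant among the compounds shown, and "the series" means these compounds.

Measured compounds:
- compound 1 `N#CC1=C(N)Oc2c(c3nc4ccccc4nc3c3ccccc23)C12C(=O)N(Cc1cnnn1-c1ccc([N+](=O)[O-])cc1)c1ccccc12`: > 50000 nM, a limit of the assay
- compound 2 `Cc1ccc(-n2nncc2CN2C(=O)C3(C(C#N)=C(N)Oc4c3c3nc5ccccc5nc3c3ccccc43)c3ccccc32)c(C)c1`: > 50000 nM, a limit of the assay
- compound 3 `CC(=O)Nc1ccc(-n2nncc2CN2C(=O)C3(C(C#N)=C(N)Oc4c(N)cc5nc6ccccc6nc5c43)c3ccccc32)cc1`: > 50000 nM, a limit of the assay

In an ADME assay on HUVEC cells (Homo sapiens) for antiproliferative activity, read by MTT assay, with a stated time of 48 h (a lower number here means a stronger inhibitor, a higher number a weaker inhibitor), compound 3 gives > 50000 nM, which is a limit of the assay rather than a number. The same holds for compound 1, which gives > 50000 nM, a limit. Compound 2 gives > 50000 nM, again a limit. Within the data shown here, all three values shown sit at the limit of > 50000 nM in this assay, at which 3 of the 3 values shown sit, so no measured step has a readable size: the only step comparable to the change of interest, a step that the two limits leave unreadable from compound 1 to compound 2, cannot be read because both ends are limits.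

Compound 4 `Cc1cc(C)c(-n2nncc2CN2C(=O)C3(C(C#N)=C(N)Oc4c(N)cc5nc6ccccc6nc5c43)c3ccccc32)c(C)c1` differs from compound 3 in one place: 2,4,6-trimethylphenyl in place of 4-acetamidophenyl on an aromatic nitrogen. Among the measured compounds shown here, the one related step exchanges the group on the same aromatic nitrogen, and it is unreadable. No direction or size beyond the scatter can therefore be drawn for compound 4 in this assay, and the expectation is that compound 4 also returns a limit. Compound 4 is expected to give 100000 nM, with a range from 50000 nM to 500000 nM. This estimate corresponds to an expected step that the limit leaves unreadable from compound 3 to compound 4, which is not expected to exceed the scatter.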

Compound 4, half-maximal inhibitory concentration: > 50000 nM
Compound 4 ended at the assay's limit (the forecaster's own chance of this, stated with the estimate: 85%); the middle value does not contradict the limit.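

The step between compound 3 and compound 4 cannot be read in this assay, since both values are limits of the assay: the limit of > 50000 nM in this assay, at which 4 of the 4 values shown sit.

The compounds shown leave open whether any group on this aromatic nitrogen would give a value inside the assay's readable range.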